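This account rests on a few compounds, and the source may have more. Where it says the series, first, only, none or still open, it means among the compounds named here.

Compound 1 `COC(=O)c1c([N+](=O)[O-])noc1-c1cccc([N+](=O)[O-])c1` gives "not determined" (no result reported) 
Compound 2 `COC(=O)c1c([N+](=O)[O-])noc1-c1cccc(-c2cnco2)c1` gives 19700 nM 
Compound 3 `O=C(Nc1ccccc1)c1c([N+](=O)[O-])noc1-c1ccc([N+](=O)[O-])cc1` gives "not determined" (no result reported) 

These entries come from an ADME assay on J774.A1 cells (Mus musculus) for cytotoxicity, read by MTT assay, with a stated time of 48 h (on this read-out higher numbers stand for lower toxicity in this test and lower numbers for higher toxicity in this test), and contain a single number. In this assay compound 3 is recorded as "not determined" (no result reported) and so has no measured position on the scale. Compound 1 likewise has no number, while compound 2 alone gives a figure, 19700 nM in this series.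

The next compound is compound 4 `CCCNC(=O)c1c([N+](=O)[O-])noc1-c1ccc([N+](=O)[O-])cc1` and it has not yet been measured. Its structural change is propyl in place of phenyl on an amide-type nitrogen in the amide part of the molecule: propyl in place of phenyl on an amide-type nitrogen, or anilino to propylamino.

Going by the values given here, no measured pair shows what such a change does. With no number for compound 3, the size of this step cannot be read from the data. The working expectation is therefore no step beyond the usual scatter, in either direction. Among the compounds with values here, the only numerical anchor is compound 2 at 19700 nM in this assay, although it differs from compound 4 in more than one place, so the range is kept wide.

For compound 4 the expected half-maximal cytotoxic concentration is an estimated 20000 nM within a range of 5000 nM to 80000 nM in this test.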

Compound 4, half-maximal cytotoxic concentration: 76200 nM
Estimate against measurement, compound 4: 3.8-fold (0.58 log units) below, within the range that was stated.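

No step can be read between compound 3 and compound 4 in this assay, as compound 3 has no single number to set against compound 4. The compounds shown leave open what the change from anilino to propylamino does to this read-out. Nothing available explains the result for compound 4.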